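From an allyl thioether to a difluorophenacyl thioether

The source may report more compounds than this note shows. Statements on the series, on what has been measured and on what is new or still open speak of the compounds shown alone.

Compound 1 `C=CCSc1nnc(CCC)n1N1C(=O)c2ccccc2C1=O` and compound 2 `C=CCSc1nnc(-c2cc(OC)c(OC)c(OC)c2)n1N1C(=O)c2ccccc2C1=O` share a core and an allylsulfanyl arm, differing only in what sits on the far side of that core. In a functional assay on HepG2 cells (Homo sapiens) for cytotoxicity, read by MTT assay, with a stated time of 48 h (a higher number here means a weaker inhibitor, a lower number a stronger inhibitor), compound 1 returns only the limit of the assay, > 200000 nM. In this assay compound 2 likewise returns only the limit, > 200000 nM, so no number places it. Among the measured compounds shown here, both measured values sit at the limit of > 200000 nM in this assay, at which 2 of the 2 values shown sit, and so no step between compound 1 and compound 2 can be read from them.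

Compound 3 `COc1cc(-c2nnc(SCC(=O)c3ccc(F)c(F)c3)n2N2C(=O)c3ccccc3C2=O)cc(OC)c1OC` differs from compound 2 in one place: (3,4-difluorophenyl)carbonyl in place of vinyl on a saturated chain carbon bound to a sulfur. For the measured compounds named here, nothing measured so far reports what such a change does in this setting.

With compound 2 reaching only the limit, the step to compound 3 cannot be anchored in a measured number, and the expected step is an at least 1.6-fold lower number from compound 2 to compound 3 (0.22 log units; that floor lies within the scatter), a move toward stronger inhibition that may or may not clear the limit. For compound 3 the estimated value in this assay is 120000 nM, with a range from 30000 nM to 300000 nM.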

Compound 3, half-maximal inhibitory concentration: > 200000 nM
Compound 3: only a limit was reported (the forecaster's own chance of this, stated with the estimate: 50%); at least 1.6-fold (0.22 log units) between middle value and limit.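

In this assay compound 3 returns > 200000 nM and this is only a limit of the assay. Among the compounds shown here, compound 2 and compound 3 both stand at that limit, so no step between them can be read: the limit of > 200000 nM in this assay, at which 3 of the 3 values shown sit.

The compounds shown leave open whether (3,4-difluorophenyl)carbonyl in place of vinyl changes the response at all.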